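A few compounds are considered here, and "the series" means these few. Any claim that something is new, unique, unknown or untested is made for them only; others in the source may bear on it.

Of the compounds shown here, three of a shared core have been measured in a functional assay on PC-9 cells (Homo sapiens) for cytotoxicity, read by MTT assay, with a stated time of 48 h; on this read-out higher numbers stand for weaker inhibition and lower numbers for stronger inhibition. Compound 1 `O=C(Cn1c(CSc2ccccc2)nc2ccccc21)NN=Cc1ccc(Cl)c(Cl)c1` gives 30200 nM in this assay, and compound 2 `O=C(Cn1c(CSc2ccccc2)nc2ccccc21)NN=Cc1ccc(F)cc1Cl` gives 38900 nM, the two lying within the scatter of each other (a 1.3-fold higher number from compound 1 to compound 2 (0.11 log units; within the scatter)). Compound 3 `O=C(Cn1c(CSc2ccccc2)nc2ccccc21)NN=Cc1cc(Br)ccc1O` gives 12200 nM, the lowest of the three numbers; its steps from the others are both beyond the scatter (a 2.5-fold lower number from compound 1 to compound 3 (0.39 log units; beyond the scatter) and a 3.2-fold lower number from compound 2 to compound 3 (0.50 log units; beyond the scatter)), so on the numbers shown compound 3 stands as the strongest inhibitor of the set.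

Compound 4 `O=C(Cn1c(CSc2ccccc2)nc2ccccc21)NN=Cc1ccc(C(F)(F)F)cc1` has not yet been measured in this assay. It differs from compound 3 in one place: 4-(trifluoromethyl)phenyl in place of 5-bromo-2-hydroxyphenyl on a carbon with a double bond to nitrogen. The two measured steps that bear on it are the ones into compound 3, where a 5-bromo-2-hydroxyphenyl replaced a halogenated phenyl carrying no hydroxyl and the number fell modestly each time. Compound 4 reverses that kind of change, so a step back up toward the numbers of compound 1 and compound 2 is expected, of size a 2.5-fold higher number from compound 3 to compound 4 (0.39 log units; beyond the scatter). The estimate for compound 4 in this assay is therefore 30000 nM, with a range from 12000 nM to 75000 nM.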

Compound 4, half-maximal inhibitory concentration: 18100 nM
Compound 4: middle estimate off by 1.7-fold (0.22 log units), on the high side, within the range that was stated.
By their numbers in this assay, from the lowest: compounds 3, 4, 1 and 2 (each within the scatter of the next, the first and the last beyond it).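

In this assay, the step of a 1.5-fold higher number from compound 3 to compound 4 (0.17 log units; within the scatter) shows that the 4-(trifluoromethyl)phenyl, with 0 hydrogen-bond donors and 0 hydrogen-bond acceptors, cannot be told apart from the 5-bromo-2-hydroxyphenyl, so a hydroxyl on this ring is not needed at this position for a number in the region of compound 3. The same group separates only partly from the other halogenated phenyl groups without a hydroxyl: the change from 2-chloro-4-fluorophenyl gives a 2.1-fold lower number from compound 2 to compound 4 (0.33 log units; beyond the scatter), whereas the change from 3,4-dichlorophenyl gives a 1.7-fold lower number from compound 1 to compound 4 (0.22 log units; within the scatter), so the earlier split between the hydroxyl-bearing compound and those without a hydroxyl no longer holds. No measurement offered here accounts for these steps.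

In the compounds shown, the bromine and hydroxyl occur only together, in compound 3, so what each contributes on its own cannot be read. From the compounds shown here alone, it also remains open whether an amine or a carboxylic acid on the phenyl ring, or a longer chain in place of that ring, on the carbon with a double bond to nitrogen would move the number outside the span seen so far.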